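A few compounds are considered here, and "the series" means these few. Any claim that something is new, unique, unknown or untested is made for them only; others in the source may bear on it.

Measured so far: compound 1 `O=C(CN(c1nc(Cl)nc2[nH]cnc12)C1CC1)N[C@@H](CCC(=O)OCc1ccccc1)C(=O)OCc1ccccc1` gives 45.9% in a functional assay on the whole organism (Tail, strain ICR) with Mus musculus as the target, in the tail flick test, with a stated time of 120 min, at a dose of 25 umol/kg by the oral route; a higher number here means a stronger effect of the compound at the dose given, a lower number a weaker effect; compound 2 `CC[C@H](C)[C@H](NC(=O)CN(c1nc(Cl)nc2[nH]cnc12)C1CC1)C(=O)OCc1ccccc1` gives 22% in this assay.

Compound 2 stands lowest of the two numbers, with compound 1 as its nearest neighbour. Compound 3 `NC(=O)CC[C@H](NC(=O)CN(c1nc(Cl)nc2[nH]cnc12)C1CC1)C(=O)OCc1ccccc1` differs from compound 2 by 2-carbamoylethyl in place of sec-butyl on a saturated chain carbon bound to an amide-type nitrogen and a carbonyl carbon. For the measured compounds named here, only one measured step bears on this change: a number 23.9 percentage points lower from compound 1 to compound 2 (beyond the scatter), where sec-butyl entered at the same place. Since a chain of comparable length now enters again, a modest rise in this assay is expected, smaller than that step. Compound 3 is expected to give 35% (range 15% to 60%), a step of a number 13 percentage points higher from compound 2 to compound 3 (beyond the scatter).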

Compound 3, a percentage reported as activity, at one dose (the size of the read-out at that dose, not a potency): 36%
Compound 3: the middle estimate sits 1 percentage points below what was measured; the range from low to high includes it.
By their numbers in this assay, from the lowest: compound 2; then compounds 3 and 1 (each within the scatter of the next).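

In this assay, placing 2-carbamoylethyl on this saturated chain carbon in place of sec-butyl gives a number 14 percentage points higher from compound 2 to compound 3 (beyond the scatter), so the drop seen with sec-butyl is not shared by every chain at this position. Amino in place of benzyloxy on a carbonyl carbon gives a number 9.9 percentage points lower from compound 1 to compound 3 (within the scatter), leaving sec-butyl as the only one of the three chains set apart by steps beyond the scatter. No measurement at hand explains either step. Still open, going by these compounds, is how a carboxylic acid at that carbonyl carbon, an amine on the chain, or a longer chain would compare.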